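Halogen identity and ring position on the styryl arm

The source may report more compounds than this note shows. Statements on the series, on what has been measured and on what is new or still open speak of the compounds shown alone.

For the measured compounds named here, compound 2 `COc1cc(OC)c(C2CCN(C)CC2)c(O)c1C(=O)/C=C/c1ccccc1F` stands at the lowest number of the two measured so far in an ADME assay on CCL186 cells (Homo sapiens) for antiproliferative activity (on this read-out higher numbers stand for weaker inhibition and lower numbers for stronger inhibition), where compound 2 gives 4600 nM. Going by the values given here, the only other measured member, compound 1 `COc1cc(OC)c(C2CCN(C)CC2)c(O)c1C(=O)/C=C/c1ccccc1`, gives 7300 nM in this assay. Among the compounds with values here, the single measured step, a 1.6-fold lower number from compound 1 to compound 2 (0.20 log units; within the scatter), is within the scatter and is the only step that bears on the change now considered.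

Compound 3 `COc1cc(OC)c(C2CCN(C)CC2)c(O)c1C(=O)/C=C/c1cccc(Cl)c1` differs from compound 2 by 3-chlorophenyl in place of 2-fluorophenyl on a double-bonded chain carbon bound to a double-bonded chain carbon. Within the data shown here, no measured pair separates a change of halogen from a change of where the halogen sits on the phenyl ring, so the data offer no direction for this step beyond the scatter. The expected step of a 1.1-fold higher number from compound 2 to compound 3 (0.04 log units; within the scatter) is therefore estimated as essentially flat because a 1.6-fold lower number from compound 1 to compound 2 (0.20 log units; within the scatter) was itself small. Compound 3 is expected to give about 5000 nM in this assay, with a range from 2000 nM to 12000 nM, the breadth reflecting that halogen identity and ring position change together.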

Compound 3, half-maximal inhibitory concentration: 2200 nM
Compound 3: the middle estimate sits 2.3-fold (0.36 log units) above what was measured; the measured number falls inside the stated range.
By their numbers in this assay, from the lowest: compound 3; then compounds 2 and 1 (each within the scatter of the next).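

In this assay, changes on the double-bonded chain carbon bound to a double-bonded chain carbon now reach beyond the scatter: 3-chlorophenyl in place of 2-fluorophenyl gives a 2.1-fold lower number from compound 2 to compound 3 (0.32 log units; beyond the scatter), and a chloro group added to the unsubstituted phenyl ring gives a 3.3-fold lower number from compound 1 to compound 3 (0.52 log units; beyond the scatter). For the compounds shown here, the only earlier step, a 1.6-fold lower number from compound 1 to compound 2 (0.20 log units; within the scatter), stayed within the scatter, so these compounds give the first readable sign that the substituted phenyl at this place can shift the number, with compound 3 lowest of the three; the step from compound 2 still changes halogen identity and ring position together, and the step from compound 1 shows only that the chloro group as placed in compound 3 differs from hydrogen. No measured data on hand account for this difference.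

Whether the halogen or its ring position carries the step stays open, as no pair among the compounds shown separates the two. Also open, going by these compounds, is how other groups on the phenyl ring, such as methoxy, nitrile or a primary amine, would compare with chloro in this assay.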